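The compounds below may be only part of what the source reports. "The series", "measured", "known", "first", "only" and "open" are said of these compounds alone.

Compound 1 `Cc1cc2c(cc1Cc1ccc(C(=O)NC[C@H]3CC[C@H](C(N)=O)CC3)o1)C(C)(C)CCC2(C)C` gives 13 nM in an assay on isolated protein for binding affinity to Gonadotropin-releasing hormone receptor (Homo sapiens); a higher number here means a weaker inhibitor, a lower number a stronger inhibitor.
Compound 2 `Cc1cc2c(cc1Cc1ccc(C(=O)NCc3ccc(CN)cc3)o1)C(C)(C)CCC2(C)C` gives 140 nM in this assay.
Compound 3 `Cc1cc2c(cc1Cc1ccc(C(=O)NCC3CCC(CN)CC3)o1)C(C)(C)CCC2(C)C` gives 42 nM in this assay.

Among these three, compound 3 holds the middle position: the step of a 3.2-fold higher number from compound 1 to compound 3 (0.51 log units; beyond the scatter) places it behind compound 1, while the step of a 3.3-fold lower number from compound 2 to compound 3 (0.52 log units; beyond the scatter) places it ahead of compound 2. The third measured step, an 11-fold higher number from compound 1 to compound 2 (1.03 log units; beyond the scatter), is the largest of the set. All three steps concern the group on the saturated chain carbon bound to the amide-type nitrogen, the 4-carbamoylcyclohexyl, 4-(aminomethyl)phenyl and 4-(aminomethyl)cyclohexyl variants.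

Compound 4 `Cc1cc2c(cc1Cc1ccc(C(=O)NCC3CCC(CNCc4c(C)noc4C)CC3)o1)C(C)(C)CCC2(C)C` departs from compound 3 in a different place: (3,5-dimethyl-1,2-oxazol-4-yl)methyl in place of hydrogen on an amine nitrogen. Within the data shown here, none of the measured steps touches this amine nitrogen, so they bear on the new step only indirectly, by showing that the terminal group of this chain matters to this assay at a modest to large scale. Among the measured compounds shown here, with no measured example of a substituent on the amine itself, the direction of the change is uncertain, and the expected step is estimated as a 1.1-fold lower number from compound 3 to compound 4 (0.02 log units; within the scatter), a change not clearly beyond the scatter. Compound 4 is therefore estimated at 40 nM, within a range from 10 nM to 160 nM.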

Compound 4, inhibition constant: 180 nM
Estimate against measurement, compound 4: 4.5-fold (0.65 log units) below; the whole stated range lies below it.
By their numbers in this assay, from the lowest: compound 1; then compound 3; then compounds 2 and 4 (each within the scatter of the next).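

Among these compounds, compound 4 gives the first view of this amine nitrogen, which the earlier steps left untouched: with (3,5-dimethyl-1,2-oxazol-4-yl)methyl in place of hydrogen, this assay shows a 4.3-fold higher number from compound 3 to compound 4 (0.63 log units; beyond the scatter). The substituent on this nitrogen therefore matters, and adding these 8 heavy atoms to the amine of the 4-(aminomethyl)cyclohexyl chain carries a cost that lies beyond the scatter, though a modest one, as compound 4 still gives 180 nM. No measurement given here accounts for this step.

As far as these compounds go, whether the higher number belongs to the (3,5-dimethyl-1,2-oxazol-4-yl)methyl group in particular or to substitution on this nitrogen in general remains open; a methyl, an acetyl or a benzyl group on the same amine would help separate these two readings. Also open, from the compounds shown here alone, is whether the same substituent would produce a step of similar size and direction on the amine nitrogen of the 4-(aminomethyl)phenyl chain in compound 2.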